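This account rests on a few compounds, and the source may have more. Where it says the series, first, only, none or still open, it means among the compounds named here.

Compound 1 `Cc1nc(Nc2ccccc2)sc1C(=O)/C=C/c1ccc(Cl)cc1` is the reference point of the series. In a functional assay on NCI-H460 cells (Homo sapiens) for cytotoxicity, read by MTT assay (on this read-out lower numbers stand for stronger inhibition and higher numbers for weaker inhibition), compound 1 gives no number, only a limit of the assay, > 25000 nM. Compound 2 `Cc1nc(Nc2ccc(Cl)cc2)sc1C(=O)/C=C/c1ccc(Cl)cc1` carries chloro in place of hydrogen on an aromatic carbon of the nitrogen-bound ring; in this assay compound 2 also returns only a limit, > 25000 nM. Compound 3 `Cc1nc(Nc2cccc(Cl)c2)sc1C(=O)/C=C/c1ccc(Cl)cc1` is the second chloro variant of that ring, and compound 3 too gives only a limit, > 25000 nM. The steps a step that the two limits leave unreadable from compound 1 to compound 2 and a step that the two limits leave unreadable from compound 1 to compound 3 are consequently not readable, and the same holds for a step that the two limits leave unreadable from compound 2 to compound 3; the only firm statement is the limit of > 25000 nM in this assay, at which 3 of the 3 values shown sit.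

Compound 4 `Cc1nc(Nc2ccccc2)sc1C(=O)/C=C/c1ccccc1Cl` remains to be measured. It differs from compound 1 by 2-chlorophenyl in place of 4-chlorophenyl on a double-bonded chain carbon bound to a double-bonded chain carbon. Going by the values given here, none of the three measured steps touches that ring; all of them concern the nitrogen-bound ring, and all are unreadable, so no measured step bears directly on this change. Among the compounds with values here, with every value so far sitting at the limit, compound 4 is expected to show no step beyond the scatter, and most probably another limit. Compound 4 is therefore estimated at 35000 nM, with a range from 10000 nM to 120000 nM. This estimate amounts to a step that the limit leaves unreadable from compound 1 to compound 4, within the scatter.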

Compound 4, half-maximal inhibitory concentration: > 25000 nM
Compound 4 ended at the assay's limit; the forecaster's own chance of this, stated with the estimate: 75%; the middle value lies beyond the limit too.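

No new step can be read, as compound 1 and compound 4 both give only a limit in this assay, and what remains firm is this: the limit of > 25000 nM in this assay, at which 4 of the 4 values shown sit.

The compounds shown leave open whether 2-chlorophenyl and 4-chlorophenyl differ at all in this assay, and whether any variant of the shared core returns a number rather than a limit.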